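Swapping Furan for Phenyl on the Shared Core

The source may report more compounds than this note shows. Statements on the series, on what has been measured and on what is new or still open speak of the compounds shown alone.

Going by the values given here, compound 1 `Oc1cccc(-c2cc(-c3cccc(Cl)c3)nc(-c3ccco3)c2)c1` is one of three compounds measured in an ADME assay on HEK293 cells (Homo sapiens) for cytotoxicity, read by CCK-8 assay and cell counting, with a stated time of 2 days; on this read-out higher numbers stand for weaker inhibition and lower numbers for stronger inhibition. In this assay compound 1 gives 2530 nM, the lowest of the three numbers. Compound 2 `Oc1cccc(-c2cc(-c3ccc(Cl)cc3)nc(-c3ccco3)c2)c1` gives 8190 nM, and compound 3 `Oc1ccc(-c2cc(-c3cccc(Cl)c3)nc(-c3ccco3)c2)cc1` gives 2880 nM. Both measured steps start from compound 1: a 3.2-fold higher number from compound 1 to compound 2 (0.51 log units; beyond the scatter) came with 4-chlorophenyl in place of 3-chlorophenyl, while a 1.1-fold higher number from compound 1 to compound 3 (0.06 log units; within the scatter) came with 4-hydroxyphenyl in place of 3-hydroxyphenyl. Compound 4 `Oc1cccc(-c2cc(-c3ccccc3)nc(-c3cccc(Cl)c3)c2)c1` differs from compound 1 at a third place: phenyl in place of furan-2-yl on an aromatic carbon. Neither measured step touches this position, so neither gives a direct guide; together they show only that altering one of the outer rings of this core changed the number by a modest amount or not at all. Among the compounds with values here, with no closer precedent, the expected step in this assay is a 1.2-fold higher number from compound 1 to compound 4 (0.07 log units; within the scatter), a change that would sit within the scatter. Compound 4 is therefore estimated at 3000 nM, with a range from 1000 nM to 9000 nM.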

Compound 4, half-maximal inhibitory concentration: 3120 nM
Compound 4: the middle estimate sits 1.0-fold (0.02 log units) below what was measured; the range from low to high includes it.
By their numbers in this assay, from the lowest: compounds 1, 3 and 4 (each within the scatter of the next); then compound 2.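

In this assay, going by these compounds alone, phenyl in place of furan-2-yl on the aromatic carbon next to the ring nitrogen gave a 1.2-fold higher number from compound 1 to compound 4 (0.09 log units; within the scatter), so this is the first measured sign that the position can take a different ring without a change beyond the scatter. The swap exchanges a five-membered aromatic ring with 1 hetero atom for a six-membered aromatic ring of carbon only, and the hydrogen-bond acceptor counted on furan-2-yl is gone, yet compound 1 and compound 4 cannot be told apart on this read-out. No measured evidence here explains this result.

From the compounds shown here alone, both groups compared at this position are aromatic rings, so it remains open how an amine, a carboxylic acid or a longer alkyl chain on this carbon would behave. Going by these compounds, it is also open whether the same swap would give a similar result with 4-chlorophenyl in place of 3-chlorophenyl, as in compound 2.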